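This account rests on a few compounds, and the source may have more. Where it says the series, first, only, none or still open, it means among the compounds named here.

Measured compounds:
Compound 1, `Nc1cc(N)c2nc(-c3ccccc3)c(NCc3ccc(Cl)c(Cl)c3)nc2c1`: 33900 nM
Compound 2, `COc1ccc(CNc2nc3cc(N)cc(N)c3nc2-c2ccccc2)cc1OC`: < 100000 nM

Compound 1 `Nc1cc(N)c2nc(-c3ccccc3)c(NCc3ccc(Cl)c(Cl)c3)nc2c1` and compound 2 `COc1ccc(CNc2nc3cc(N)cc(N)c3nc2-c2ccccc2)cc1OC` share one core and differ only in the aryl group on the saturated chain carbon bound to the ring nitrogen. In a functional assay on COLO 205 cells (Homo sapiens) for inhibition, read by sulforhodamine B assay, with a stated time of 48 h (a higher number here means a weaker inhibitor of growth, a lower number a stronger inhibitor of growth), compound 1 gives 33900 nM. For compound 2 the assay returns a limit rather than a number, < 100000 nM, so compound 2 stands on that limit alone (the limit of < 100000 nM in this assay, at which 1 of the 2 values shown sits). The step that the limit leaves unreadable from compound 1 to compound 2 is accordingly not readable.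

Compound 3 `COc1cc(CNc2nc3cc(N)cc(N)c3nc2-c2ccccc2)cc(OC)c1OC` differs from compound 2 by methoxy in place of hydrogen on an aromatic carbon. For the measured compounds named here, no measured pair concerns a methoxy entering an aromatic carbon, and the single recorded step is itself unreadable, so nothing among the measurements speaks to the size or direction of this change in this assay. The expectation therefore rests on compound 2 alone. Compound 3 is expected to show a step that the limit leaves unreadable from compound 2 to compound 3 that stays within the scatter. The estimate for compound 3 is 50000 nM, with a range from 15000 nM to 100000 nM.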

Compound 3, concentration for total growth inhibition: < 50200 nM
Compound 3: a limit, no number; the forecaster's own chance of this, stated with the estimate: 40%; the middle value lies beyond the limit too.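

In this assay, compound 3 gives only a limit, < 50200 nM, and compound 2 also stands on a limit, so the step between these two compounds cannot be read. The compounds shown leave open whether methoxy in place of hydrogen on an aromatic carbon changes growth inhibition at all, and in which direction.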